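Solubility notes on a nitro-trifluoromethyl series

The compounds below may be only part of what the source reports. "The series", "measured", "known", "first", "only" and "open" are said of these compounds alone.

Three compounds of the shared core have been run in a physicochemical assay for solubility, measured as kinetic solubility, at pH 7.4; on this read-out higher numbers stand for higher solubility and lower numbers for lower solubility. Compound 1 `CN(C(=O)CN1CCN(c2nc(=O)c3cc(C(F)(F)F)cc([N+](=O)[O-])c3s2)CC1)c1ccccc1` gives 11900 nM, the highest of the three numbers. Compound 3 `CCN(CCN(C)C)c1nc(=O)c2cc(C(F)(F)F)cc([N+](=O)[O-])c2s1` gives 10600 nM in this assay, which sits within the scatter of the number for compound 1. Compound 2 `CN(c1nc(=O)c2cc(C(F)(F)F)cc([N+](=O)[O-])c2s1)[C@H]1CCN(Cc2ccccc2)C1` gives 2970 nM in this assay, a gap to compound 1 that lies beyond the scatter. Going by the values given here, no two of these three differ in only one place, so no single-point step between measured compounds is available.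

Compound 4 `O=C(c1ccoc1)N1CCN(c2nc(=O)c3cc(C(F)(F)F)cc([N+](=O)[O-])c3s2)CC1` is the next compound for this assay and differs from compound 1 in one place: (furan-3-yl)carbonyl in place of (methyl(phenyl)carbamoyl)methyl on an amine nitrogen in a ring. Among the compounds with values here, no measured pair shows what such an exchange on the ring nitrogen does in this assay, so the expectation rests on compound 1 alone, with its value of 11900 nM as the anchor. The step from compound 1 to compound 4 is expected to be small, at most a modest move downward, and it may well fall within the scatter; the estimate is a 1.5-fold lower number from compound 1 to compound 4 (0.17 log units; within the scatter). On that basis compound 4 is expected to give about 8000 nM in this assay, with a range from 2500 nM to 25000 nM.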

Compound 4, solubility: 21800 nM
Compound 4: the middle estimate sits 2.7-fold (0.44 log units) below what was measured; measured number inside the range.
By their numbers in this assay, from the lowest: compound 2; then compounds 3, 1 and 4 (each within the scatter of the next, the first and the last beyond it).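

On the amine nitrogen in the six-membered non-aromatic ring with 2 nitrogen, (furan-3-yl)carbonyl in place of (methyl(phenyl)carbamoyl)methyl gives a 1.8-fold higher number from compound 1 to compound 4 (0.26 log units; within the scatter) in this assay, the first single-point step available for the series. The step lies within the usual scatter, so the two compounds cannot be told apart on this read-out, and no gain can be claimed for the exchange; it does show that this nitrogen can carry either a 7-heavy-atom group with a five-membered aromatic ring or an 11-heavy-atom group with a six-membered aromatic ring of carbon only, with no separation between them in this assay. Nothing at hand bears on why the two groups read alike.

A single step cannot show whether this holds as a rule for the position, and compounds 2 and 3 differ from compound 1 in more than one place, so they add nothing to it. Open, from the compounds shown here alone, is how a group of another kind on the same ring nitrogen would read, such as a simple acetyl, a chain ending in a carboxylic acid, or a chain ending in a primary amine.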